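The source may hold more compounds than are shown below. What is called first, only, known or untested is meant among the compounds shown, and "the series" means these compounds.

Compound 1 `COc1ccccc1-c1cc(-c2ccc(F)cc2)c(C#N)c(OC)n1` gives 75 nM in an assay on isolated protein for inhibition of sulfide:quinone oxidoreductase, mitochondrial (Homo sapiens) (a higher number here means a weaker inhibitor, a lower number a stronger inhibitor), the lowest of the two numbers in hand. Compound 3 `COc1nc(-c2ccccc2)cc(-c2ccncc2)c1C#N` gives 541 nM in this assay, a higher number. Compound 2 `COc1nc(-c2ccccc2)cc(-c2ccc(Cl)cc2Cl)c1C#N` sits at a limit of this assay, > 100000 nM, which is the limit of > 100000 nM in this assay, at which 1 of the 3 values shown sits, and not a number. Going by the values given here, the one measured step, an at least 180-fold lower number from compound 2 to compound 3 (2.26 log units; beyond the scatter), shows that swapping an aryl for a pyridyl on the shared core can move this assay greatly. Compound 4 `COc1nc(-c2ncccc2C)cc(-c2ccc(F)cc2)c1C#N` differs from compound 1 by 3-methylpyridin-2-yl in place of 2-methoxyphenyl on an aromatic carbon. Among the compounds with values here, no measured step matches this exact change, so only a modest shift is expected, toward a somewhat higher number. Compound 4 is therefore estimated at 200 nM, between 40 nM and 1000 nM, an expected step of a 2.7-fold higher number from compound 1 to compound 4 (0.43 log units; beyond the scatter).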

Compound 4, half-maximal inhibitory concentration: 8.7 nM
Compound 4: the middle estimate sits 23-fold (1.36 log units) above what was measured; measured number below the stated range.
By their numbers in this assay, from the lowest: compound 4; then compound 1; then compound 3. At a limit, above all of these: compound 2.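

This change shows that the position next to the ring nitrogen, not only the group changed in the earlier step, responds strongly in this assay, with an 8.6-fold lower number from compound 1 to compound 4 (0.94 log units; beyond the scatter). The swap alters a ring atom and the small group on that ring together, so the step cannot say which of the two matters. Nothing measured here explains the gain. Still open, as far as these compounds go, is whether plain pyridin-2-yl without the methyl, or a ring carrying an amine or a carboxylic acid at this position, would keep such a low number.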